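Removing the benzyl from the ether: compound 3 to compound 4

The source may report more compounds than this note shows. Statements on the series, on what has been measured and on what is new or still open speak of the compounds shown alone.

Measured compounds:
Compound 1 `O=S(=O)(CCCN1CCc2cc(OCc3ccccc3)ccc2C(O)C1)c1ccccc1` gives 349 nM in an assay for displacement of a labelled ligand from Sigma non-opioid intracellular receptor 1 (Cavia porcellus), read by scintillation counting, with a stated time of 180 min; a higher number here means a weaker inhibitor, a lower number a stronger inhibitor.
Compound 2 `COc1ccc(C2(CCCN3CCc4cc(OCc5ccccc5)ccc4C(O)C3)OCC(C)(C)CO2)cc1` gives > 1000 nM in this assay, a limit rather than a number.
Compound 3 `O=C(c1ccccc1)N1CCC(N2CCc3cc(OCc4ccccc4)ccc3C(O)C2)CC1` gives > 1000 nM in this assay, again a limit rather than a number.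

Compound 3 thus stands at the limit of > 1000 nM in this assay, at which 2 of the 3 values shown sit. Among the three compounds shown, only compound 1 has a number; for compound 3 the assay reports only the limit, so its distance from compound 1 cannot be read off, and no pair of measured compounds differs in a single place.

Compound 4 `O=C(c1ccccc1)N1CCC(N2CCc3cc(O)ccc3C(O)C2)CC1` follows from compound 3 by hydrogen in place of benzyl on an oxygen on an aromatic ring; the benzyloxy of compound 3 becomes a hydroxy. Compound 3 starts at the limit, so the direction of any step can only be guessed. Compound 4 is expected to remain at or beyond the limit, so the step from compound 3 to compound 4 is estimated as a step that the limit leaves unreadable from compound 3 to compound 4. For compound 4 the estimate in this assay is 3000 nM, within a range from 800 nM to 15000 nM.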

Compound 4, inhibition constant: > 1000 nM
Compound 4 ended at the assay's limit (the forecaster's own chance of this, stated with the estimate: 75%); the middle value is on the limit's open side.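

Within the data shown here, compound 3 and compound 4 both give only a limit rather than a number in this assay, so no step between them can be read: the limit of > 1000 nM in this assay, at which 3 of the 4 values shown sit. The compounds shown leave open how far past that limit compound 3 and compound 4 lie, and whether hydrogen in place of benzyl on an oxygen on an aromatic ring changes their binding at all.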